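The compounds below may be only part of what the source reports. "The series", "measured", "known", "first", "only" and "open" are said of these compounds alone.

Working notes on the series. In a functional assay on JeKo-1 cells (Homo sapiens) for inhibition, read by luminescence and CellTiter-Glo, with a stated time of 72 h (a higher number here means a weaker inhibitor, a lower number a stronger inhibitor), compound 1 `C=CC(=O)Nc1ccc(Cn2nc(-c3ccc(Oc4ccccc4)cc3)cc2C(=O)O)cc1` gives only a limit, > 60000 nM. Compound 3 `C=CC(=O)Nc1cccc(Cn2nc(-c3ccc(Oc4ccccc4)cc3)cc2C(=O)O)c1` likewise gives only a limit in this assay, > 60000 nM. Compound 3 therefore stands at the limit of > 60000 nM in this assay, at which 2 of the 3 values shown sit, and the step that the two limits leave unreadable from compound 1 to compound 3 cannot be read from two limits. For the measured compounds named here, compound 2 `CCOC(=O)c1cc(-c2ccc(Oc3ccccc3)cc2)nn1Cc1cccc(NC(=O)CCl)c1` gives 400 nM in this assay; it differs from compound 3 in two places, so no single step joins them, and their values show only that one compound returns a number while the other does not. Compound 4 `O=C(CCl)Nc1cccc(Cn2nc(-c3ccc(Oc4ccccc4)cc3)cc2C(=O)O)c1` carries chloromethyl in place of vinyl on a carbonyl carbon. Going by the values given here, no measured step isolates this change, and both compounds sharing the core of compound 3 sit at the limit, so little movement beyond the scatter is expected. Compound 4 is estimated at 30000 nM, in a range from 3000 nM to 90000 nM. The expected step is an at least 2.0-fold lower number from compound 3 to compound 4 (0.30 log units; that floor lies within the scatter).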

Compound 4, half-maximal inhibitory concentration: 6300 nM
Estimate against measurement, compound 4: 4.8-fold (0.68 log units) above; low and high end bracket the measured number.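

In this assay, chloromethyl in place of vinyl on a carbonyl carbon turns a limit into a readable number, an at least 9.5-fold lower number from compound 3 to compound 4 (0.97 log units; beyond the scatter), and only the floor of that step is known: the limit of > 60000 nM in this assay, at which 2 of the 4 values shown sit.

Hydrogen in place of ethyl on an oxygen next to a carbonyl group also matters with the chloromethyl group in place, a 16-fold higher number from compound 2 to compound 4 (1.20 log units; beyond the scatter). The change from 4-((vinylcarbonyl)amino)phenyl to 3-(((chloromethyl)carbonyl)amino)phenyl gives an at least 9.5-fold lower number from compound 1 to compound 4 (0.97 log units; beyond the scatter), but it alters ring position and group together.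

Open, on these data alone, is how 4-(((chloromethyl)carbonyl)amino)phenyl would read on the shared core. Also open, as far as these compounds go, is whether a longer chain in place of chloromethyl keeps a readable number.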